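Adding a Second Trifluoromethyl Group to Compound 3

A few compounds are considered here, and "the series" means these few. Any claim that something is new, unique, unknown or untested is made for them only; others in the source may bear on it.

Compound 1 `COc1cc(-c2c(C)nn(-c3nc(-c4ccc(Cl)c(Cl)c4)c(SC(C)C)s3)c2C(=O)O)cc(C(F)(F)F)c1` — 1380 nM
Compound 2 `Cc1nn(-c2nc(-c3ccc(Cl)c(Cl)c3)c(SC(C)C)s2)c(C(=O)O)c1-c1ccc(Cl)cc1` — 2500 nM
Compound 3 `Cc1nn(-c2nc(-c3ccc(Cl)c(Cl)c3)c(SC(C)C)s2)c(C(=O)O)c1-c1cccc(C(F)(F)F)c1` — 22000 nM

In a functional assay on BJAB cells (Homo sapiens) for antiproliferative activity, with a stated time of 4 days (on this read-out lower numbers stand for an effect already at smaller amounts and higher numbers for an effect only at larger amounts of compound), compound 3 gives the highest of the three numbers. Its nearest neighbour is compound 2, reached by an 8.8-fold higher number from compound 2 to compound 3 (0.94 log units; beyond the scatter), and the furthest is compound 1, reached by a 16-fold higher number from compound 1 to compound 3 (1.20 log units; beyond the scatter). Compound 4 `Cc1nn(-c2nc(-c3ccc(Cl)c(Cl)c3)c(SC(C)C)s2)c(C(=O)O)c1-c1cc(C(F)(F)F)cc(C(F)(F)F)c1` differs from compound 3 by trifluoromethyl in place of hydrogen on an aromatic carbon. The step that bears most directly on this change is a 16-fold higher number from compound 1 to compound 3 (1.20 log units; beyond the scatter), where removing a methoxy group from that position raised the number strongly; compound 4 puts a trifluoromethyl group back in the same place. The step of an 8.8-fold higher number from compound 2 to compound 3 (0.94 log units; beyond the scatter) shows that the pattern of groups on this ring shifts the read-out well beyond the scatter. A lower number than that of compound 3 is therefore expected in this assay, though smaller than the methoxy step. For compound 4 the estimate is 3500 nM, with a range from 900 nM to 14000 nM, which corresponds to an expected step of a 6.3-fold lower number from compound 3 to compound 4 (0.80 log units; beyond the scatter).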

Compound 4, half-maximal effective concentration: 1800 nM
Compound 4: middle estimate off by 1.9-fold (0.29 log units), on the high side; low and high end bracket the measured number.
By their numbers in this assay, from the lowest: compounds 1, 4 and 2 (each within the scatter of the next); then compound 3.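

Placing trifluoromethyl on the hydrogen-bearing aromatic carbon of compound 3 gives a 12-fold lower number from compound 3 to compound 4 (1.09 log units; beyond the scatter) in this assay, so the gain seen earlier with methoxy at this place is not confined to that group. Trifluoromethyl and methoxy cannot be told apart here, with a 1.3-fold higher number from compound 1 to compound 4 (0.12 log units; within the scatter), which means that of the three occupants compared at this place, only hydrogen stands apart, and this rests on compound 1, compound 3 and compound 4 alone. Nothing available explains why either group has this effect.

On these data alone, whether any group at this place would do the same remains open, as an amine, a carboxylic acid or a longer chain there could behave differently. Going by these compounds alone, it is also open whether this step carries over to cores other than the one shared by these compounds.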